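Small Amine Swaps on a Benzodiazepine-Type Amide Chain

The source may report more compounds than this note shows. Statements on the series, on what has been measured and on what is new or still open speak of the compounds shown alone.

Measured compounds:
Compound 1 `CC(C)NCC(=O)NCC(=O)N(C)c1ccc(Cl)cc1C(=O)c1ccccc1Cl` — 1 mg/kg
Compound 2 `CCN(CC)CC(=O)NCC(=O)N(C)c1ccc(Cl)cc1C(=O)c1ccccc1Cl` — 2.2 mg/kg
Compound 3 `CN(C(=O)CNC(=O)CN1CCN(c2ccccc2)CC1)c1ccc(Cl)cc1C(=O)c1ccccc1Cl` — 75 mg/kg

Of the compounds shown here, three sharing one core have been tested in a functional assay on the whole organism for antagonist activity, with Mus musculus as the target; on this read-out lower numbers stand for an effect already at smaller amounts and higher numbers for an effect only at larger amounts of compound. Compound 1 gives 1 mg/kg, the lowest of the three numbers. Its nearest neighbour is compound 2; the step of a 2.2-fold higher number from compound 1 to compound 2 (0.34 log units; beyond the scatter) is modest. Compound 3 sits far off, with a 75-fold higher number from compound 1 to compound 3 (1.88 log units; beyond the scatter) and, from the diethyl analogue, a 34-fold higher number from compound 2 to compound 3 (1.53 log units; beyond the scatter), both large.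

Compound 4 `CN(C)CC(=O)NCC(=O)N(C)c1ccc(Cl)cc1C(=O)c1ccccc1Cl` has not yet been measured in this assay. Its difference from compound 1 is dimethylamino in place of isopropylamino on a saturated chain carbon bound to a carbonyl carbon. The step that bears on it most directly is a 2.2-fold higher number from compound 1 to compound 2 (0.34 log units; beyond the scatter), where a tertiary amine likewise replaced the isopropylamino group and the number rose only modestly. The large steps to compound 3 involve a far bigger group and are less relevant. Since dimethylamino is smaller than diethylamino, the step is expected to be small, a 1.6-fold higher number from compound 1 to compound 4 (0.20 log units; within the scatter), lying near or just beyond the scatter and upward if anything. Compound 4 is therefore estimated at 1.6 mg/kg, in the range 0.6 mg/kg to 4.5 mg/kg.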

Compound 4, dose for half-maximal effect: 2.6 mg/kg
Compound 4: the middle estimate sits 1.6-fold (0.21 log units) below what was measured, within the range that was stated.
By their numbers in this assay, from the lowest: compound 1; then compounds 2 and 4 (each within the scatter of the next); then compound 3.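

In this assay dimethylamino in place of isopropylamino gives a 2.6-fold higher number from compound 1 to compound 4 (0.41 log units; beyond the scatter) and so a second group with no hydrogen-bond donor, after diethylamino, stands modestly but readably apart from compound 1. Between these two groups the position shows no readable preference, with a 1.2-fold higher number from compound 2 to compound 4 (0.07 log units; within the scatter) and the size of the alkyl groups on this nitrogen, across this pair, does not separate compound 2 from compound 4. The large gap to compound 3 appears from this new side too, at a 29-fold lower number from compound 3 to compound 4 (1.46 log units; beyond the scatter) and among the groups seen the high number therefore goes with 4-phenylpiperazin-1-yl and not with every tertiary amine at this place.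

Still open, as far as these compounds go, is whether other secondary amines, such as methylamino or tert-butylamino, would stay as close to compound 1 as the isopropylamino group's number suggests. Simple ring amines such as piperidin-1-yl or morpholin-4-yl would show whether the ring itself or the phenyl on 4-phenylpiperazin-1-yl goes with the high number of compound 3. Nothing measured here accounts for any of these steps.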